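Cyclohexyl in place of benzyl on the shared core

The source may hold more compounds than are shown below. What is called first, only, known or untested is meant among the compounds shown, and "the series" means these compounds.

Compound 2 `O=C(CCCCCc1ccccc1)OCC1COCCOCCOCCOCCOCCO1` is an ester built on the same core as two companions. In a functional assay on WiDr cells (Homo sapiens) for inhibition, read by sulforhodamine B assay, with a stated time of 48 h (on this read-out lower numbers stand for stronger inhibition of growth and higher numbers for weaker inhibition of growth), compound 2 gives > 100000 nM, which is a limit of the assay and not a number. Compound 1 `O=C(/C=C/c1ccccc1)OCC1COCCOCCOCCOCCOCCO1` gives the limit > 100000 nM in this assay. Compound 3 `O=C(CCCCC1CCCCC1)OCC1COCCOCCOCCOCCO1` gives the limit > 100000 nM. The step that the two limits leave unreadable from compound 1 to compound 2 cannot be read from two limits. Compound 4 `O=C(CCCCC1CCCCC1)OCC1COCCOCCOCCOCCOCCO1` differs from compound 2 by cyclohexyl in place of benzyl on a saturated chain carbon, four bonds along the chain from a carbonyl carbon. Among the compounds with values here, no measured step bears on this change, since every value shown sits at the same limit (the limit of > 100000 nM in this assay, at which 3 of the 3 values shown sit). The expected step that the limit leaves unreadable from compound 2 to compound 4 is therefore of no readable size. Compound 4 is estimated at 150000 nM, within a range from 50000 nM to 500000 nM.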

Compound 4, concentration for 50% growth inhibition: 33000 nM
For compound 4 the middle estimate is 4.5-fold (0.66 log units) above the measured one; measured number below the stated range.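

In this assay, cyclohexyl in place of benzyl, on a saturated chain carbon four bonds along the chain from a carbonyl carbon, gives an at least 3.0-fold lower number from compound 2 to compound 4 (0.48 log units; beyond the scatter), so a change at this position can move growth inhibition into a range the assay can read. Likewise, 4-cyclohexylbutyl in place of 2-phenylethenyl on a carbonyl carbon gives an at least 3.0-fold lower number from compound 1 to compound 4 (0.48 log units; beyond the scatter). Both sizes are only lower bounds because the starting compounds sit at a limit, and the step between those two limits cannot be read: the limit of > 100000 nM in this assay, at which 3 of the 4 values shown sit.

On these data alone, whether a longer chain would lower the number further remains open. So does the effect of an amine on the cyclohexyl ring.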